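A Flat Series Meets a 4-Methoxyphenyl Swap

This account rests on a few compounds, and the source may have more. Where it says the series, first, only, none or still open, it means among the compounds named here.

In a functional assay on L1210 cells (Mus musculus) for cytotoxicity, read by MTT assay (on this read-out lower numbers stand for stronger inhibition and higher numbers for weaker inhibition), compound 1 `COc1ccc(/C=N/NC(=O)c2cn(C3CC3)c3cc(N4CCNCC4)c(F)cc3c2=O)cc1O` gives 25000 nM, compound 2 `COc1cc(/C=N/NC(=O)c2cn(C3CC3)c3cc(N4CCNCC4)c(F)cc3c2=O)cc(OC)c1OC` gives 25000 nM and compound 3 `O=C(N/N=C/c1ccccc1O)c1cn(C2CC2)c2cc(N3CCNCC3)c(F)cc2c1=O` gives 25000 nM. Compound 3 therefore stands level with the other two at the digits reported.

Compound 4 `COc1ccc(/C=N/NC(=O)c2cn(C3CC3)c3cc(N4CCNCC4)c(F)cc3c2=O)cc1` has not yet been measured. It differs from compound 3 in one place: 4-methoxyphenyl in place of 2-hydroxyphenyl on a carbon with a double bond to nitrogen.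

Three measured exchanges at that same place bear on this change: no change at the digits printed from compound 1 to compound 2 (within the scatter), no change at the digits printed from compound 1 to compound 3 (within the scatter) and no change at the digits printed from compound 2 to compound 3 (within the scatter). All three stay within the scatter, so no step beyond the scatter, in either direction, is expected in this assay. Going by the values given here, none of the measured compounds carries 4-methoxyphenyl itself, so this expectation rests on its neighbours alone. The estimated change is no change at the digits printed from compound 3 to compound 4 (within the scatter). For compound 4 the estimated value is 25000 nM, with an expected range from 14000 nM to 40000 nM.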

Compound 4, half-maximal inhibitory concentration: 25000 nM
Beside the measured number, compound 4's estimate shows no gap at the digits printed; measured number inside the range.
By their numbers in this assay, from the lowest: compounds 1, 2, 3 and 4 (each within the scatter of the next).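

Going by these compounds alone, the reading in this assay shows no change at the digits printed from compound 1 to compound 4 (within the scatter) when hydrogen replaces hydroxy on an aromatic carbon, the first exchange here that removes a single group and leaves the rest of the ring as it was. Going from 3,4,5-trimethoxyphenyl to 4-methoxyphenyl gives no change at the digits printed from compound 2 to compound 4 (within the scatter) and going from 2-hydroxyphenyl to 4-methoxyphenyl gives no change at the digits printed from compound 3 to compound 4 (within the scatter) on the same read-out. Among these four compounds, then, neither the hydroxy group nor the additional methoxy groups move the reading beyond the scatter at this position.

Every group shown here is a phenyl ring carrying only hydroxy or methoxy groups, so an amine or a carboxylic acid on that ring, or a pyridine in its place, remains open. Nothing available explains why these compounds read alike.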